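A few compounds are considered here, and "the series" means these few. Any claim that something is new, unique, unknown or untested is made for them only; others in the source may bear on it.

Compound 1 `OC[C@H]1O[C@@H](n2cnc3c(NCc4ccccc4Cl)ncnc32)[C@H](O)[C@@H]1O`: 64000 nM
Compound 2 `OC[C@H]1O[C@@H](n2cnc3c(NCc4ccccc4Br)ncnc32)[C@H](O)[C@@H]1O`: 10000 nM

These values come from a functional assay on K562 cells (Homo sapiens) for antiproliferative activity, with a stated time of 72 h (on this read-out higher numbers stand for weaker inhibition and lower numbers for stronger inhibition), and compound 2 holds the lower of the two numbers. Compound 3 `OC[C@H]1O[C@@H](n2cnc3c(NCc4cccc(Br)c4)ncnc32)[C@H](O)[C@@H]1O` has the same atoms as compound 2, joined differently: 3-bromophenyl in place of 2-bromophenyl on a saturated chain carbon bound to a nitrogen on an aromatic ring. For the measured compounds named here, the only measured step is a 6.4-fold lower number from compound 1 to compound 2 (0.81 log units; beyond the scatter), a modest one that swaps chloro for bromo on an aromatic carbon. It does not test this kind of change, so it gives no direction and only a rough sense of how far the numbers can move. The expected change is a 1.4-fold higher number from compound 2 to compound 3 (0.15 log units; within the scatter), with no clear step beyond the scatter. For compound 3 the estimated value is 14000 nM, with an expected range from 3000 nM to 70000 nM.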

Compound 3, half-maximal inhibitory concentration: 19700 nM
The estimate for compound 3 lay 1.4-fold (0.15 log units) below the measured number; the measured number falls inside the stated range.
By their numbers in this assay, from the lowest: compounds 2 and 3 (each within the scatter of the next); then compound 1.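

Placing the bromine as 3-bromophenyl rather than 2-bromophenyl gives a 2.0-fold higher number from compound 2 to compound 3 (0.29 log units; within the scatter) in this assay, so this change of attachment point does not separate the two compounds on this read-out. The larger step, a 3.2-fold lower number from compound 1 to compound 3 (0.51 log units; beyond the scatter), changes both the halogen and where it sits, so it cannot be credited to either change alone. No evidence is available to explain these results.

The compounds shown leave open how the number would respond to a different group on the phenyl ring, such as an amine or a carboxylic acid.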